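Thiophene in Place of Fluorobenzyl on a Stable Core

The source may hold more compounds than are shown below. What is called first, only, known or untested is meant among the compounds shown, and "the series" means these compounds.

Compound 1 `Cc1nc(C)c([C@H](OC(C)(C)C)C(=O)O)c(N2CCC(C)(C)CC2)c1-c1ccc(OCCc2cc(F)c(F)cc2F)cc1` and compound 2 `Cc1nc(C)c([C@H](OC(C)(C)C)C(=O)O)c(N2CCC(C)(C)CC2)c1-c1ccc(OCCCc2ccc(F)cc2)cc1` share one core and differ only in the group sitting on a saturated chain carbon, two bonds along the chain from an oxygen on an aromatic ring. In an ADME assay on microsomes from liver (Homo sapiens) for metabolic stability, read by LC-MS, tested at 0.5 uM (a higher number here means that the compound lasts longer, a lower number that the compound disappears faster), compound 1 gives > 2 h, which is a limit of the assay rather than a number. In this assay compound 2 gives > 2 h, again a limit rather than a number. The step that the two limits leave unreadable from compound 1 to compound 2 therefore cannot be read, as the limit of > 2 h in this assay, at which 2 of the 2 values shown sit, shows. Compound 2 thus stands at the upper edge of what this assay reports, side by side with compound 1.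

Compound 3 `Cc1ccc(CCOc2ccc(-c3c(C)nc(C)c([C@H](OC(C)(C)C)C(=O)O)c3N3CCC(C)(C)CC3)cc2)s1` arises from compound 2 through the change (5-methylthiophen-2-yl in place of 4-fluorobenzyl on a saturated chain carbon, two bonds along the chain from an oxygen on an aromatic ring). Going by the values given here, the only measured step in this assay concerns the same place in the molecule but gives no size, so neither direction nor magnitude can be drawn from it. Compound 3 is expected to stay near the limit, with the step of an at least 1.2-fold lower number from compound 2 to compound 3 (0.09 log units; that floor lies within the scatter) expected to remain within the scatter. Compound 3 is accordingly estimated at 1.6 h, with a range from 0.6 h to 3.5 h.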

Compound 3, half-life: > 2 h
Compound 3: no number, only a limit; the forecaster's own chance of this, stated with the estimate: 45%; middle value at least 1.2-fold (0.09 log units) away from the limit.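

In this assay compound 3 gives > 2 h as a limit of the assay and not a number. Going by these compounds alone, no step among compound 1, compound 2 and compound 3 can be read, because all three values sit at one edge: the limit of > 2 h in this assay, at which 3 of the 3 values shown sit.

These compounds leave open how long each one lasts, and so whether 5-methylthiophen-2-yl in place of 4-fluorobenzyl changes the half-life at all.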